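Swapping the amide substituent of a lipopeptide-like toll-like receptor 2 agonist

The source may report more compounds than this note shows. Statements on the series, on what has been measured and on what is new or still open speak of the compounds shown alone.

Measured so far:
compound 1, `CCCCCCCCCCCC(=O)OC[C@H](CSC[C@@H](N)C(=O)N[C@@H](C)CO)OC(=O)CCCCCCCCCCC`: 1560 nM
compound 2, `CCCCCCCCCCCC(=O)OC[C@H](CSC[C@@H](N)C(=O)NC(C)c1ccccc1)OC(=O)CCCCCCCCCCC`: 9900 nM

Both compounds share the same lipidated core and differ only in the group on the amide-type nitrogen. In an assay on HEK293 cells for agonist activity at Toll-like receptor 2 (Homo sapiens) (a lower number here means that less compound is needed, a higher number that more compound is needed for the effect), compound 2 gives the highest of the two numbers, so more of it is needed than of compound 1; the step of a 6.3-fold higher number from compound 1 to compound 2 (0.80 log units; beyond the scatter) lies beyond the scatter.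

Compound 3, `CCCCCCCCCCCC(=O)OC[C@H](CSC[C@@H](N)C(=O)NCCCn1ccnc1)OC(=O)CCCCCCCCCCC`, has not yet been measured. It differs from compound 2 as follows: 3-(1H-imidazol-1-yl)propyl in place of 1-phenylethyl on an amide-type nitrogen.

For the measured compounds named here, only one measured step bears on this change, a 6.3-fold higher number from compound 1 to compound 2 (0.80 log units; beyond the scatter), and it shows that the group on the amide-type nitrogen can shift the number by a modest amount. The entering 3-(1H-imidazol-1-yl)propyl group carries acceptors, as the 1-(hydroxymethyl)ethyl group of compound 1 does, while the leaving 1-phenylethyl group carries none, so a move back toward compound 1 is expected, a 2.5-fold lower number from compound 2 to compound 3 (0.39 log units; beyond the scatter). Compound 3 is therefore estimated at 4000 nM, between 1200 nM and 13000 nM.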

Compound 3, half-maximal effective concentration: 410 nM
Compound 3: middle estimate off by 9.8-fold (0.99 log units), on the high side; measured number below the stated range.
By their numbers in this assay, from the lowest: compound 3; then compound 1; then compound 2.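

In this assay, putting 3-(1H-imidazol-1-yl)propyl in place of 1-phenylethyl on the amide-type nitrogen gives a 24-fold lower number from compound 2 to compound 3 (1.38 log units; beyond the scatter) and so shows that this position can shift the number much further than the first pair suggested. The same group also goes past the 1-(hydroxymethyl)ethyl group, with a 3.8-fold lower number from compound 1 to compound 3 (0.58 log units; beyond the scatter), so this is more than a return to the level of compound 1, and compound 3 needs the least compound of the three. Nothing available here explains why this group gives the lowest number.

The three compounds leave open whether the imidazole ring or the propyl chain matters more, since the ring and the chain both differ from the groups in compound 1 and compound 2. A 3-phenylpropyl group would separate these two parts, and a butyl chain carrying the same imidazole ring would test the chain length.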